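This account rests on a few compounds, and the source may have more. Where it says the series, first, only, none or still open, it means among the compounds named here.

Compound 1 `CCCCc1cnc(C(CCC)Cc2ccc(-c3ccccc3C(=O)O)cc2)[nH]1` gives 165 nM in an in vitro functional assay on cells for agonist activity at Bombesin receptor subtype-3 (Mus musculus), read by luminescence and calcium flux; on this read-out higher numbers stand for an effect only at larger amounts of compound and lower numbers for an effect already at smaller amounts. Compound 2 `CCCCc1cnc(CCCc2ccc(-c3ccccc3C(=O)O)cc2)[nH]1` gives 382 nM. Compound 3 `COc1cccc(Cc2cnc(CCc3ccc(-c4ccccc4C(=O)O)cc3)[nH]2)c1` gives 79 nM.

Of these three, compound 3 shows the lowest number in this assay; compound 1 stands nearest and compound 2 furthest, both beyond the usual scatter. The unmeasured compound 4 `N#Cc1cccc(Cc2cnc(CCc3ccc(-c4ccccc4C(=O)O)cc3)[nH]2)c1` differs from compound 3 in one place: cyano in place of methoxy on an aromatic carbon. Going by the values given here, no pair of measured compounds shares this change, so nothing here shows how large a step it brings. The expected step is a 1.3-fold higher number from compound 3 to compound 4 (0.10 log units; within the scatter), small and not clearly beyond the scatter, in either direction. Compound 4 is therefore estimated at 100 nM, within a range from 35 nM to 300 nM.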

Compound 4, half-maximal effective concentration: 20 nM
Compound 4: the middle estimate sits 5.0-fold (0.70 log units) above what was measured; measured number below the stated range.
By their numbers in this assay, from the lowest: compound 4; then compound 3; then compound 1; then compound 2.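

In this assay cyano in place of methoxy brings a 4.0-fold lower number from compound 3 to compound 4 (0.60 log units; beyond the scatter) on this aromatic carbon, so the group here clearly matters. The number moves even though both groups have the same heavy-atom count and one hydrogen-bond acceptor each, so those counts alone do not set it. Nothing measured here explains the step.

From the compounds shown here alone, whether an amine, a hydroxyl or a fluorine at this place would give a lower or higher number stays open. So does whether the same swap would bring a similar step on the cores of compound 1 or compound 2.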